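Notes on the step from compound 2 to compound 3

The source may hold more compounds than are shown below. What is called first, only, known or untested is meant among the compounds shown, and "the series" means these compounds.

compound 1 `CNc1cccc(NC(=O)C(=O)O)c1C#N` gives 0.07 mg/kg
compound 2 `CCCNc1cccc(NC(=O)C(=O)OCC)c1C#N` gives 0.7 mg/kg

In a functional assay on the whole organism with Rattus norvegicus as the target (a higher number here means that more compound is needed for the effect, a lower number that less compound is needed), compound 2 at 0.7 mg/kg carries the higher of the two numbers, and its gap to compound 1 lies beyond the usual scatter. These two compounds differ in more than one place, so neither value isolates the next change. Compound 3 `CCOC(=O)C(=O)Nc1cccc(C)c1C#N` follows from compound 2 by methyl in place of propylamino on an aromatic carbon with methyl in place of propylamino on an aromatic carbon, ortho to a cyano group. Going by the values given here, no measured pair shows what this exchange does. A small rise in the number is expected, with the estimated step of a 2.1-fold higher number from compound 2 to compound 3 (0.33 log units; beyond the scatter) perhaps staying within the scatter. The estimate for compound 3 is 1.5 mg/kg with 0.3 mg/kg as the lower end and 7 mg/kg as the upper end of the expected range.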

Compound 3, dose for half-maximal effect: 4.6 mg/kg
Compound 3: the middle estimate sits 3.1-fold (0.49 log units) below what was measured; low and high end bracket the measured number.
By their numbers in this assay, from the lowest: compound 1; then compound 2; then compound 3.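

Methyl in place of propylamino on an aromatic carbon, ortho to a cyano group, gives a 6.6-fold higher number from compound 2 to compound 3 (0.82 log units; beyond the scatter) in this assay, so more compound is needed for the effect after this exchange. Going by these compounds alone, this is the only step that isolates this position, as compound 1 and compound 2 differ in more than one place and could not show the effect of this change alone. The exchange removes the nitrogen along with the chain, and no measurement here explains the rise.

The step leaves open whether the nitrogen, the chain or both account for the change. An unsubstituted amine, a methoxy group or a longer alkyl chain at this position could separate these, while a carboxylic acid in place of the ethyl ester remains a separate open question.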